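The compounds below may be only part of what the source reports. "The series", "measured", "known", "first", "only" and "open" are said of these compounds alone.

Working notes on the series. Of the compounds shown here, two of the shared core have been measured in an assay for inhibition of Amine oxidase [flavin-containing] B (Homo sapiens), read by fluorescence, using microsomes, with a stated time of 30 min; a higher number here means a weaker inhibitor, a lower number a stronger inhibitor. Compound 1 `Cc1c(C)c2ccc(OCc3cccc(CN4CCC(CO)CC4)c3)cc2oc1=O` gives 320 nM in this assay. Compound 2 `Cc1c(C)c2ccc(OCC3CCCN(Cc4ccc(CO)cc4)C3)cc2oc1=O` gives 76 nM in this assay, the lowest of the two numbers; the gap to compound 1 is beyond the usual scatter of repeated measurements. Compound 3 `Cc1c(C)c2ccc(OCC3CCCN(Cc4cccc(CO)c4)C3)cc2oc1=O` has not yet been measured. It differs from compound 2 only in the placement of the hydroxymethyl group on the benzyl substituent: 3-(hydroxymethyl)phenyl in place of 4-(hydroxymethyl)phenyl on a saturated chain carbon bound to an amine nitrogen in a ring. Going by the values given here, no measured pair isolates this change, so there is no direct precedent to lean on. For this assay, the step from compound 2 to compound 3 is expected to be small, most likely toward a somewhat higher number, and may well sit within the scatter; the estimated step is a 2.0-fold higher number from compound 2 to compound 3 (0.30 log units; within the scatter). On that basis compound 3 is expected to give about 150 nM in this assay, with a plausible range from 50 nM to 500 nM.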

Compound 3, half-maximal inhibitory concentration: 110 nM
The estimate for compound 3 lay 1.4-fold (0.13 log units) above the measured number; low and high end bracket the measured number.
By their numbers in this assay, from the lowest: compounds 2 and 3 (each within the scatter of the next); then compound 1.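

Going by these compounds alone, this is the first pair that differs in one place: in this assay, 3-(hydroxymethyl)phenyl in place of 4-(hydroxymethyl)phenyl on a saturated chain carbon bound to an amine nitrogen in a ring gives a 1.4-fold higher number from compound 2 to compound 3 (0.16 log units; within the scatter). The two placements of the hydroxymethyl group therefore cannot be told apart in this assay, and at this position the read-out stays in the same range with either one. Nothing in hand explains why the two placements read alike.

Compound 1 differs from both compounds in more than one place, so it says nothing about this change. Still open, on these data alone, is whether the hydroxymethyl group itself matters, which a bare benzyl, a carboxylic acid, an amine or a longer hydroxyethyl chain on the same ring would test.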